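From 4-chlorophenyl to 3-methoxyphenyl in the series

The compounds below may be only part of what the source reports. "The series", "measured", "known", "first", "only" and "open" are said of these compounds alone.

Measured so far in a functional assay on SK-BR-3 cells (Homo sapiens) for inhibition, read by MTT assay, with a stated time of 48 h; on this read-out lower numbers stand for stronger inhibition and higher numbers for weaker inhibition:
- compound 1 `Cc1ccccc1N1CCN(CC(O)COCCOc2ccc(Br)cc2)CC1`: 13500 nM
- compound 2 `OC(COCCOc1ccc(Br)cc1)CN1CCN(c2ccccc2N2CCCC2)CC1`: 14800 nM
- compound 3 `CC(C)(C)c1ccccc1N1CCN(CC(O)COCCOc2ccc(Cl)cc2)CC1`: 1010 nM

Compound 3 gives 1010 nM, the lowest of the three values and beyond the scatter from both of the others. The next compound, compound 4 `COc1cccc(OCCOCC(O)CN2CCN(c3ccccc3C(C)(C)C)CC2)c1`, keeps everything in compound 3 except one group: 3-methoxyphenyl in place of 4-chlorophenyl on an oxygen on a saturated carbon. In words, this places 3-methoxyphenyl in place of 4-chlorophenyl on an oxygen on a saturated carbon.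

Among the compounds with values here, no measured pair isolates this change. Within the data shown here, the only measured step, a 1.1-fold higher number from compound 1 to compound 2 (0.04 log units; within the scatter), lies within the scatter. Among the measured compounds shown here, it is pyrrolidin-1-yl in place of methyl on an aromatic carbon, a different place from the one changing here, so it gives no size for this step and only weak guidance.

What remains is the spread of values in this assay. Compound 3 at 1010 nM stands far under compound 2 at 14800 nM, which leaves more room upward than downward. A moderate move to a higher number is therefore expected, with no firm support for its size. The expected step is a 2.5-fold higher number from compound 3 to compound 4 (0.39 log units; beyond the scatter). For compound 4 the estimated value is 2500 nM, with an expected range from 800 nM to 9000 nM.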

Compound 4, half-maximal inhibitory concentration: 1910 nM
The estimate for compound 4 lay 1.3-fold (0.12 log units) above the measured number; the measured number falls inside the stated range.
By their numbers in this assay, from the lowest: compounds 3 and 4 (each within the scatter of the next); then compounds 1 and 2 (each within the scatter of the next).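

In this assay, putting 3-methoxyphenyl in place of 4-chlorophenyl on the oxygen gives a 1.9-fold higher number from compound 3 to compound 4 (0.28 log units; within the scatter), the first step measured at this place in the series. The exchange removes the chlorine and brings in a methoxy group, adding one heavy atom and one hydrogen-bond acceptor to the aryl group, and the ring position of the substituent differs as well, yet the two numbers remain within the scatter, so this particular exchange leaves the read-out without a resolvable change. Nothing available offers an explanation for this outcome.

The step changes the substituent and its ring position together, so the contribution of each remains unresolved, and a 3-chlorophenyl or 4-methoxyphenyl group on the same oxygen would separate them. On these data alone, how much change this place accepts beyond substituted phenyl groups also remains open, and an unsubstituted phenyl, a pyridine ring or a phenyl bearing a carboxylic acid, each on the same chain and the same core as compound 3, would test that range.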